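Swapping Bromo for Nitro on a Shared Core

This account rests on a few compounds, and the source may have more. Where it says the series, first, only, none or still open, it means among the compounds named here.

Measured so far:
compound 1 `CCOC(=O)C12C(=O)OCC=C1COC2c1ccc(F)cc1` — > 1000000 nM
compound 2 `CCOC(=O)C12C(=O)OCC=C1COC2c1ccc(Br)cc1` — > 1000000 nM

In a functional assay on QGY cells (Homo sapiens) for cytotoxicity, read by MTT assay (on this read-out higher numbers stand for weaker inhibition and lower numbers for stronger inhibition), compound 1 gives > 1000000 nM, and this is a limit of the assay rather than a number. In this assay compound 2 gives > 1000000 nM, again a limit and not a number. Going by the values given here, the single measured step, a step that the two limits leave unreadable from compound 1 to compound 2, is therefore unreadable because both ends sit at the limit of > 1000000 nM in this assay, at which 2 of the 2 values shown sit. Compound 2 thus stands at the limit of this assay, with no number of its own to compare against.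

Compound 3 `CCOC(=O)C12C(=O)OCC=C1COC2c1ccc([N+](=O)[O-])cc1` differs from compound 2 in one place: nitro in place of bromo on an aromatic carbon. Among the compounds with values here, the only measured step that bears on such a change at that position is the one from compound 1 to compound 2, and its size cannot be read. No readable step gives a direction, so the expectation for compound 3 rests on where compound 2 stands. Compound 3 is estimated at 1500000 nM in this assay, within a range of 300000 nM to 10000000 nM. The step that the limit leaves unreadable from compound 2 to compound 3 is expected to be none beyond the scatter.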

Compound 3, half-maximal inhibitory concentration: > 1000000 nM
Compound 3: only a limit was reported; the forecaster's own chance of this, stated with the estimate: 85%; the middle value does not contradict the limit.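

In this assay compound 3 gives > 1000000 nM, which is a limit and not a number. The steps among compound 1, compound 2 and compound 3 therefore cannot be read, because all three stop at the same limit: the limit of > 1000000 nM in this assay, at which 3 of the 3 values shown sit.

The compounds shown leave open whether fluoro, bromo and nitro on the shared core differ at all in this assay.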